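Acetyl for chloro on the aryl arm of compound 3

This account rests on a few compounds, and the source may have more. Where it says the series, first, only, none or still open, it means among the compounds named here.

Compound 3 `CCCC(C)n1c(CC)nc2c(-c3ccc(Cl)cc3Cl)ccnc21` holds the lowest number of the three in an assay for binding affinity to Corticotropin releasing factor receptor (Rattus norvegicus) (a higher number here means a weaker inhibitor, a lower number a stronger inhibitor), at 0.5 nM. Compound 1 `CCCC(C)n1c(CC)nc2c(-c3ccc(/C(C)=N\OC)cc3Cl)ccnc21` gives 2.3 nM in this assay, and compound 2 `CCCC(C)n1c(CC)nc2c(-c3ccc(C(C)OC)cc3Cl)ccnc21` gives 3.5 nM. Compound 4 `CCCC(C)n1c(CC)nc2c(-c3ccc(C(C)=O)cc3Cl)ccnc21` differs from compound 3 by acetyl in place of chloro on an aromatic carbon. Two measured steps reach compound 3 through a change at the same aromatic carbon: a 4.6-fold lower number from compound 1 to compound 3 (0.66 log units; beyond the scatter) and a 7.0-fold lower number from compound 2 to compound 3 (0.85 log units; beyond the scatter). Both replace a larger group by chloro and both lower the number, so the reverse move, chloro to acetyl, is expected to raise it by a modest step. Acetyl is a smaller group than those the two steps removed, so a step somewhat below theirs is estimated, a 4.0-fold higher number from compound 3 to compound 4 (0.60 log units; beyond the scatter). Compound 4 is expected at 2 nM, within 0.8 nM to 5 nM.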

Compound 4, inhibition constant: 1 nM
Estimate against measurement, compound 4: 2.0-fold (0.30 log units) above, within the range that was stated.
By their numbers in this assay, from the lowest: compounds 3 and 4 (each within the scatter of the next); then compounds 1 and 2 (each within the scatter of the next).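

In this assay acetyl and chloro on this aromatic carbon are not told apart: a 2.0-fold higher number from compound 3 to compound 4 (0.30 log units; within the scatter). The site therefore tolerates a group larger than chloro that carries a hydrogen-bond acceptor, so added size alone does not set the number. The same acetyl still separates from the two larger groups, with a 3.5-fold lower number from compound 2 to compound 4 (0.54 log units; beyond the scatter) and a 2.3-fold lower number from compound 1 to compound 4 (0.36 log units; beyond the scatter). No measurement shown gives a reason for these steps. Open, as far as these compounds go, is whether an amine, a carboxylic acid or a longer chain on this carbon would sit with compound 3 and compound 4 or with compound 1 and compound 2.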